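A Larger Aryl Group on an Inactive Pair

The source may report more compounds than this note shows. Statements on the series, on what has been measured and on what is new or still open speak of the compounds shown alone.

In a functional assay on KYSE-70 cells for antiproliferative activity against KYSE-70 cell line (Homo sapiens), read by MTT assay, with a stated time of 72 h (on this read-out higher numbers stand for weaker inhibition and lower numbers for stronger inhibition), compound 1 (`O=C(Nc1cccc(F)c1)c1cc(=O)[nH]c2cc(-c3ccccc3F)ccc12`) gives > 20000 nM as a limit of the assay, not a true number. Compound 2 (`O=C(Nc1cccc(F)c1)c1cc(=O)[nH]c2cc(-c3cccnc3F)ccc12`) likewise gives > 20000 nM as a limit. Compound 2 thus stands at the limit of > 20000 nM in this assay, at which 2 of the 2 values shown sit, and has no exact value. Compound 3 (`Cc1cc(-c2ccc3c(C(=O)Nc4cccc(F)c4)cc(=O)[nH]c3c2)c(C)cc1F`) carries 4-fluoro-2,5-dimethylphenyl in place of 2-fluoropyridin-3-yl on an aromatic carbon, and the counted difference is 4-fluoro-2,5-dimethylphenyl in place of 2-fluoropyridin-3-yl on an aromatic carbon in full. Among the compounds with values here, the only measured step is a step that the two limits leave unreadable from compound 1 to compound 2 and it offers no size to carry forward, so there is no firm ground for expecting a change beyond the scatter in either direction. The expected move is a number no higher from compound 2 to compound 3 (the limit leaves the size open) as an estimate only. For compound 3 the estimated value is 20000 nM with an expected range of 7000 nM to 50000 nM and another limit is quite likely.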

Compound 3, half-maximal inhibitory concentration: > 20000 nM
Compound 3 was reported as a limit (the forecaster's own chance of this, stated with the estimate: 65%); the middle value sits exactly at the limit.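

In this assay, within the data shown here, compound 1, compound 2 and compound 3 are each reported only as a limit, so no step among them can be read. The compounds shown leave open whether any other aryl group at this place on the shared core would give a true number.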